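The source may hold more compounds than are shown below. What is called first, only, known or untested is meant among the compounds shown, and "the series" means these compounds.

In a functional assay on PC-12 cells (Rattus norvegicus) for cytotoxicity, read by MTT assay, with stated times of 2 h and 24 h, tested at 5 uM (on this read-out higher numbers stand for a stronger effect at the one concentration tested and lower numbers for a weaker effect), compound 1 `Cc1ccc(-n2nc(-c3ccc(C(F)(F)F)cc3O)nc2-c2ccccc2O)cc1` gives 94.1%. Compound 2 `N#Cc1ccc(-n2nc(-c3ccc(C(F)(F)F)cc3O)nc2-c2ccccc2O)cc1` gives 86.8% in this assay. Compound 3 `Oc1cc(C(F)(F)F)ccc1-c1nc(-c2ccccc2O)n(-c2ccccc2C(F)(F)F)n1` gives 80% in this assay. Among the three numbers measured, compound 3 has the lowest; its gap to compound 2 lies within the scatter, while the step of a number 14.1 percentage points lower from compound 1 to compound 3 (beyond the scatter) lies beyond it.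

Compound 4 `COc1ccccc1-n1nc(-c2ccc(C(F)(F)F)cc2O)nc1-c1ccccc1O` is not yet measured. It differs from compound 3 in one place: methoxy in place of trifluoromethyl on an aromatic carbon.

Two measured steps alter the group on the aromatic nitrogen of the shared core. The step of a number 14.1 percentage points lower from compound 1 to compound 3 (beyond the scatter) is modest, and the step of a number 6.8 percentage points lower from compound 2 to compound 3 (within the scatter) stays within the scatter. No measured step, however, exchanges one substituent for another on the ring attached to that nitrogen, so nothing shown speaks directly to the exchange of trifluoromethyl for methoxy. All three exchanges seen so far on that ring moved the number by little, which suggests that the step from compound 3 to compound 4 in this assay is expected to be small, with no clear direction, as a number 4 percentage points higher from compound 3 to compound 4 (within the scatter) expresses. Compound 4 is therefore estimated at 84%, with a range from 68% to 97%.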

Compound 4, a percentage reported as activity, at one concentration (the size of the read-out at that concentration, not a potency): 85.6%
Beside the measured number, compound 4's estimate is 1.6 percentage points below it; the range from low to high includes it.
By their numbers in this assay, from the lowest: compounds 3, 4, 2 and 1 (each within the scatter of the next, the first and the last beyond it).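

Among the compounds shown here, the exchange of trifluoromethyl for methoxy is the first measured change of a substituent on the ring attached to the aromatic nitrogen, at an aromatic carbon ortho to a large group, and in this assay it gives a number 5.6 percentage points higher from compound 3 to compound 4 (within the scatter). So at this position, replacing trifluoromethyl with methoxy, which adds a hydrogen-bond acceptor, leaves the read-out within the usual scatter. The 2-methoxyphenyl group also stays within the scatter of the other two nitrogen substituents, with a number 1.2 percentage points lower from compound 2 to compound 4 (within the scatter) and a number 8.5 percentage points lower from compound 1 to compound 4 (within the scatter), whereas the 2-(trifluoromethyl)phenyl group was separated from the 4-methylphenyl group by a number 14.1 percentage points lower from compound 1 to compound 3 (beyond the scatter); no measurement of any property accompanies these numbers, so the size of these steps remains unexplained.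

The compounds shown leave open whether this position would tolerate a very different group, such as an amine or a carboxylic acid, in place of methoxy, or whether methoxy would give a similar number at another carbon of the same ring. Each number also comes from a single concentration, so none of these small steps reveals whether the compounds differ in potency.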